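The compounds below may be only part of what the source reports. "The series", "measured", "known", "first", "only" and "open" are said of these compounds alone.

Among the measured compounds shown here, compound 3 `CC[C@H](C)[C@@H]1C(=O)N[C@H](C2Cc3ccccc3C2)C(=O)N1[C@@H](C(=O)N(C)C)c1cnc(C)cc1C` stands at the low end of the three numbers so far: in an assay on isolated protein for displacement of a labelled ligand from Oxytocin receptor (Homo sapiens) (on this read-out lower numbers stand for stronger inhibition and higher numbers for weaker inhibition), compound 3 gives 0.0398 nM. Compound 1 `CC[C@H](C)[C@@H]1C(=O)N[C@H](C2Cc3ccccc3C2)C(=O)N1[C@@H](C(=O)N(C)C)c1ccc(C)nc1C` gives 0.0794 nM in this assay, and the step of a 2.0-fold lower number from compound 1 to compound 3 (0.30 log units; within the scatter) lies within the scatter, so the two cannot be told apart. For the measured compounds named here, compound 2 `CC[C@H](C)[C@@H]1C(=O)N[C@H](C2Cc3ccccc3C2)C(=O)N1[C@@H](C(=O)N1CCOCC1)c1cc(C)cnc1C` gives 0.794 nM, which is beyond the scatter from compound 3, but compound 2 differs from compound 3 in two places at once, in the amide as well as in the pyridine, so no single step is drawn from it.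

Compound 4 `CC[C@H](C)[C@@H]1C(=O)N[C@H](C2Cc3ccccc3C2)C(=O)N1[C@@H](C(=O)N(C)C)c1cc(C)cnc1C` is the next step: 2,5-dimethylpyridin-3-yl in place of 4,6-dimethylpyridin-3-yl on a saturated chain carbon bound to an amide-type nitrogen in a ring and a carbonyl carbon. Going by the values given here, the only measured step that bears directly on a rearrangement of the methyls around the pyridine is a 2.0-fold lower number from compound 1 to compound 3 (0.30 log units; within the scatter), which is within the scatter. Compound 4, however, carries the same pyridine as compound 2, whose number sits well beyond the scatter from compound 3, while keeping the dimethylamide of compound 3. The expected step is therefore a 5.0-fold higher number from compound 3 to compound 4 (0.70 log units; beyond the scatter), a moderate rise in the number, with wide uncertainty. Compound 4 is expected to give 0.2 nM in this assay, with a likely range from 0.05 nM to 0.8 nM.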

Compound 4, inhibition constant: 0.794 nM
Beside the measured number, compound 4's estimate is 4.0-fold (0.60 log units) below it; the range from low to high includes it.
By their numbers in this assay, from the lowest: compounds 3 and 1 (each within the scatter of the next); then compounds 2 and 4 (each within the scatter of the next).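

In this assay, the arrangement of the two methyl groups on the pyridine proves to matter at this position, a point the within-scatter step between the 2,6-dimethylpyridin-3-yl and 4,6-dimethylpyridin-3-yl compounds had not revealed: the 2,5-dimethylpyridin-3-yl group gives a 20-fold higher number from compound 3 to compound 4 (1.30 log units; beyond the scatter) and a 10-fold higher number from compound 1 to compound 4 (1.00 log units; beyond the scatter). With that pyridine held fixed, dimethylamino in place of morpholin-4-yl on the carbonyl carbon gives no change at the digits printed from compound 2 to compound 4 (within the scatter), so this amide change has no visible effect on the number in this one pyridine setting. No measurement is available to explain why the 2,5-dimethylpyridin-3-yl group stands apart from the other two arrangements.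

The compounds shown leave open whether the morpholin-4-yl amide would also match the dimethylamino amide when paired with the 4,6-dimethylpyridin-3-yl or 2,6-dimethylpyridin-3-yl group. They also leave open how the number would respond if one of the methyl groups on the pyridine gave way to a methoxy group, an ethyl group or a chlorine atom, or if a plain phenyl ring took the place of the pyridine.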